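Notes on ring substitution in the B1 antagonist series

A few compounds are considered here, and "the series" means these few. Any claim that something is new, unique, unknown or untested is made for them only; others in the source may bear on it.

Compound 1 `Cc1nc(-c2c(F)cc(Cl)cc2-c2cnc([C@@H](C)NC(=O)N(C)O)c(F)c2)no1` carries a methyl on the saturated chain carbon and a fluoro on the six-membered aromatic ring with one nitrogen. For the measured compounds named here, in a functional assay on IMR-90 cells for antagonist activity at B1 bradykinin receptor (Homo sapiens), read by calcium flux (on this read-out lower numbers stand for stronger inhibition and higher numbers for weaker inhibition), compound 1 gives 1.2 nM, the lowest of the three numbers so far. Compound 3 `Cc1nc(-c2c(Cl)cc(Cl)cc2-c2cnc([C@@H](C)NC(=O)N(C)O)c(F)c2)no1` gives 2.3 nM; the step of a 1.9-fold higher number from compound 1 to compound 3 (0.28 log units; within the scatter) stays within the scatter. Compound 2 `Cc1nc(-c2c(F)cc(Cl)cc2-c2cnc(CNC(=O)N(C)O)c(F)c2)no1` gives 17 nM; the step of a 14-fold higher number from compound 1 to compound 2 (1.15 log units; beyond the scatter) is the one large effect seen.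

Compound 4 `Cc1nc(-c2c(F)cc(Cl)cc2-c2cnc([C@@H](C)NC(=O)N(C)O)c(C)c2)no1` differs from compound 1 by methyl in place of fluoro on an aromatic carbon, placed ortho to the 1-((hydroxy(methyl)carbamoyl)amino)ethyl group, two atoms from the ring nitrogen and meta to a large group. The chain methyl of compound 1 is kept, so the large step to compound 2 does not bear on this change. Going by the values given here, the only comparable step is the swap of one ring substituent for another in a 1.9-fold higher number from compound 1 to compound 3 (0.28 log units; within the scatter), which was within the scatter, though it sits on the other ring. Among the compounds with values here, no measured pair covers a substituent change on this ring at this position.

On that basis a small step is expected, a 1.7-fold higher number from compound 1 to compound 4 (0.22 log units; within the scatter), with no clear direction beyond the scatter. Compound 4 is estimated at 2 nM, within 0.6 nM to 7 nM.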

Compound 4, half-maximal inhibitory concentration: 3.6 nM
For compound 4 the middle estimate is 1.8-fold (0.26 log units) below the measured one, and the stated range covers the measured number.
By their numbers in this assay, from the lowest: compounds 1, 3 and 4 (each within the scatter of the next, the first and the last beyond it); then compound 2.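

At the position ortho to the 1-((hydroxy(methyl)carbamoyl)amino)ethyl group and two atoms from the ring nitrogen, the choice of substituent does register in this assay: methyl in place of fluoro gives a 3.0-fold higher number from compound 1 to compound 4 (0.48 log units; beyond the scatter), a modest step that lies beyond the scatter. For the compounds shown here, this is the first measured substituent change at this position, and it shows that fluoro is not required for activity here, since compound 4 still stands at 3.6 nM, although methyl does not fully match fluoro. The step remains far smaller than the large effect of removing the chain methyl, a 14-fold higher number from compound 1 to compound 2 (1.15 log units; beyond the scatter), and nothing measured for these compounds bears on why methyl and fluoro differ at this position.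

With only fluoro and methyl shown at this position, it remains open whether hydrogen, chloro, methoxy or a nitrile would stay close to compound 1 or move further from it. Going by these compounds, it also remains open whether the methyl-for-fluoro step keeps its size when the other ring carries the chloro of compound 3, or when the chain carbon carries only hydrogen as in compound 2.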